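Chloro Added to a Second Core: Expected Growth Inhibition

A few compounds are considered here, and "the series" means these few. Any claim that something is new, unique, unknown or untested is made for them only; others in the source may bear on it.

Of the compounds shown here, three have been measured in a functional assay on SK-MEL-28 cells (Homo sapiens) for inhibition, read by MTT assay, with a stated time of 72 h; on this read-out higher numbers stand for weaker inhibition of growth and lower numbers for stronger inhibition of growth. Compound 1 `OC1CCCN(C(=S)Sc2c(-c3ccc(Br)cc3)[nH]c3ccccc23)C1` gives 28000 nM in this assay. Compound 3 `OC1CCCN(C(=S)Sc2c(-c3ccc(Br)cc3)[nH]c3ccc(Cl)cc23)C1` differs from compound 1 in one place only: chloro in place of hydrogen on an aromatic carbon. In this assay compound 3 gives 34000 nM. The step is a 1.2-fold higher number from compound 1 to compound 3 (0.08 log units; within the scatter), so the two numbers cannot be told apart.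

Compound 2 `CCOC(=O)C1CCN(C(=S)Sc2c(-c3ccc(Br)cc3)[nH]c3ccccc23)CC1` carries a different core from compound 1; the difference between the two cores is not broken down here. In this assay compound 2 gives 36000 nM. The three measured numbers all lie within the scatter of one another, so none of them can be called stronger or weaker than the others.

Compound 4 `CCOC(=O)C1CCN(C(=S)Sc2c(-c3ccc(Br)cc3)[nH]c3ccc(Cl)cc23)CC1` has not yet been measured. It stands to compound 2 as compound 3 stands to compound 1: chloro in place of hydrogen on an aromatic carbon. The place of the new chloro is described in the same words for both pairs, so this is the same change made on the core of compound 2 instead of the core of compound 1. The expected step is a 1.2-fold higher number from compound 2 to compound 4 (0.07 log units; within the scatter), a step within the scatter, because the same change made a 1.2-fold higher number from compound 1 to compound 3 (0.08 log units; within the scatter). Nothing among these compounds points to the change behaving differently on the second core. Compound 4 is therefore expected to give about 42000 nM in this assay, most likely between 20000 nM and 85000 nM.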

Compound 4, concentration for 50% growth inhibition: 39000 nM
Compound 4: the middle estimate sits 1.1-fold (0.03 log units) above what was measured, within the range that was stated.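

In this assay, chloro in place of hydrogen on an aromatic carbon gives a 1.1-fold higher number from compound 2 to compound 4 (0.03 log units; within the scatter), so the two numbers cannot be told apart. Set beside the earlier step, the same change reads alike on the two cores, and nothing separates one step from the other: the same change on two cores in this assay, a 1.2-fold higher number (0.08 log units; within the scatter) from compound 1 to compound 3 and a 1.1-fold higher number (0.03 log units; within the scatter) from compound 2 to compound 4, 1.1-fold (0.05 log units) apart, within the scatter of two such steps. This shows that, on these two cores and at this one place, adding chloro left the number within the scatter both times, but it does not show that steps carry over from core to core in general, since a step too small to read offers only a weak test, and a change with a clear effect on one core might or might not keep that effect on the other.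

The compounds shown leave open whether a different group at this place, such as a methoxy group, an amine or a carboxylic acid, would move the number beyond the scatter on either core, and whether that step would then be the same size on both. They also leave open whether chloro on another aromatic carbon, or on a third core, would behave as it does in these two pairs.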